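A few compounds are considered here, and "the series" means these few. Any claim that something is new, unique, unknown or untested is made for them only; others in the source may bear on it.

`CN(C)c1ccc(NC(=O)c2cc(Cl)ccc2O)c(Cl)c1` is compound 1, which gives 85100 nM in an ADME assay on A549 cells (Homo sapiens) for cytotoxicity, read by resazurin assay, with a stated time of 48 h (on this read-out lower numbers stand for higher toxicity in this test and higher numbers for lower toxicity in this test), as its measured result. Compound 2 `O=C(Nc1ccc(NCc2cc(F)cc(Cl)c2)cc1Cl)c1cc(Cl)ccc1O` gives 11100 nM in this assay and so holds the lower of the two numbers, with a gap to compound 1 that lies beyond the scatter. Compound 3 `O=C(Nc1ccc(NCc2ccc(Br)s2)cc1Cl)c1cc(Cl)ccc1O` differs from compound 2 by 5-bromothiophen-2-yl in place of 3-chloro-5-fluorophenyl on a saturated chain carbon bound to a nitrogen on an aromatic ring in a single place, with 5-bromothiophen-2-yl in place of 3-chloro-5-fluorophenyl on a saturated chain carbon bound to a nitrogen on an aromatic ring. Among the compounds with values here, no measured pair shows a change of this kind, so the expectation rests on compound 2 at 11100 nM as the closest measured structure. No change beyond the scatter is expected in this assay for the estimated 1.1-fold lower number from compound 2 to compound 3 (0.05 log units; within the scatter) in either direction. For compound 3 the expected value is 10000 nM with an estimated range from 4000 nM to 25000 nM at this stage.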

Compound 3, half-maximal cytotoxic concentration: 20700 nM
Estimate against measurement, compound 3: 2.1-fold (0.32 log units) below, and the stated range covers the measured number.
By their numbers in this assay, from the lowest: compounds 2 and 3 (each within the scatter of the next); then compound 1.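

In this assay, putting 5-bromothiophen-2-yl in place of 3-chloro-5-fluorophenyl on a saturated chain carbon bound to a nitrogen on an aromatic ring gives a 1.9-fold higher number from compound 2 to compound 3 (0.27 log units; within the scatter), so this position tolerates the change from a six-membered aromatic ring of carbon only to a five-membered one with a hetero atom without a difference that can be told from the scatter. The second step, with ((5-bromothiophen-2-yl)methyl)amino in place of dimethylamino on an aromatic carbon, gives a 4.1-fold lower number from compound 1 to compound 3 (0.61 log units; beyond the scatter), the first single-place change shown to go beyond the scatter, though only modestly. Nothing at hand explains the size of either step.

Going by these compounds, what a longer alkyl chain or a carboxylic acid would give in place of the aromatic ring on that saturated chain carbon remains open. Also open, on these data alone, is whether the step from dimethylamino depends on the bromine of the 5-bromothiophen-2-yl group or on the ring alone.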